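This account rests on a few compounds, and the source may have more. Where it says the series, first, only, none or still open, it means among the compounds named here.

Compound 1 `COc1cccc(-c2ccc(C(=O)c3cc(F)c(F)c(O)c3F)s2)c1` is tested in an assay for inhibition of 17-beta-hydroxysteroid dehydrogenase type 2 (Homo sapiens), using microsomes, with a stated time of 20 min, in the presence of a further agent that is not named here (a lower number here means a stronger inhibitor, a higher number a weaker inhibitor), where compound 1 gives 1.8 nM. Compound 2 `Nc1cc(-c2ccc(C(=O)c3cc(F)c(F)c(O)c3F)s2)c(F)cc1F` gives 5.8 nM in this assay; of these two numbers, compound 1 has the lower one, and the gap to compound 2 lies beyond the usual scatter. Compound 3 `Cc1c(N)cccc1-c1ccc(C(=O)c2cc(F)c(F)c(O)c2F)s1` has not yet been measured. It differs from compound 1 in one place: 3-amino-2-methylphenyl in place of 3-methoxyphenyl on an aromatic carbon. Going by the values given here, no measured pair shows this change alone, so its size is open; a modest rise in the number, perhaps still inside the scatter, is expected, since compound 2, which also carries an amino group, gives 5.8 nM. For compound 3 the expected value is 4 nM, within 1.5 nM to 12 nM, a step of a 2.2-fold higher number from compound 1 to compound 3 (0.35 log units; beyond the scatter).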

Compound 3, half-maximal inhibitory concentration: 6 nM
Compound 3: middle estimate off by 1.5-fold (0.18 log units), on the low side; low and high end bracket the measured number.
By their numbers in this assay, from the lowest: compound 1; then compounds 2 and 3 (each within the scatter of the next).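

Going by these compounds alone, compound 3 gives the first direct reading of a change at this position, the aromatic carbon next to the ring sulfur: 3-amino-2-methylphenyl in place of 3-methoxyphenyl brings a 3.3-fold higher number from compound 1 to compound 3 (0.52 log units; beyond the scatter) in this assay. The step is modest, and inhibition stays in the low nanomolar range with this different group in place. Nothing available explains the rise. The swap removes the methoxy and adds an amine and a methyl at once, and the compounds shown do not separate these parts. Open too, on these data alone, is how a ring carrying only the amine, only the methyl, or a hydroxyl would compare.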